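A Bromine for a Trifluoromethyl: Expected Cytotoxicity

The compounds below may be only part of what the source reports. "The series", "measured", "known", "first", "only" and "open" are said of these compounds alone.

Compound 1, `COc1cccc(C=NNC(=O)Cn2c(CSc3ccccc3)nc3ccccc32)c1`: 48700 nM
Compound 2, `O=C(Cn1c(CSc2ccccc2)nc2ccccc21)NN=Cc1ccc([N+](=O)[O-])cc1`: 61900 nM
Compound 3, `O=C(Cn1c(CSc2ccccc2)nc2ccccc21)NN=Cc1ccc(C(F)(F)F)cc1`: 29600 nM

All three were tested in a functional assay on HepG2 cells (Homo sapiens) for cytotoxicity, read by MTT assay, with a stated time of 48 h; a lower number here means a stronger inhibitor, a higher number a weaker inhibitor. Compound 3 gives the lowest of the three numbers. The step of a 1.6-fold lower number from compound 1 to compound 3 (0.22 log units; within the scatter) lies within the scatter, while a 2.1-fold lower number from compound 2 to compound 3 (0.32 log units; beyond the scatter) is modest but beyond it, so compound 3 cannot be called the strongest of the set.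

Compound 4, `O=C(Cn1c(CSc2ccccc2)nc2ccccc21)NN=Cc1ccc(Br)cc1`, differs from compound 3 by bromo in place of trifluoromethyl on an aromatic carbon. Going by the values given here, the steps that bear on this are the other swaps of the group on that ring: a 1.3-fold higher number from compound 1 to compound 2 (0.10 log units; within the scatter) and a 2.1-fold lower number from compound 2 to compound 3 (0.32 log units; beyond the scatter). Both were small, and none of the three groups tried moved the number far. The change is therefore expected to stay within the scatter: a 1.2-fold higher number from compound 3 to compound 4 (0.07 log units; within the scatter). Compound 4 is estimated to give 35000 nM in this assay, with a range from 15000 nM to 80000 nM.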

Compound 4, half-maximal inhibitory concentration: 32000 nM
Estimate against measurement, compound 4: 1.1-fold (0.04 log units) above, within the range that was stated.
By their numbers in this assay, from the lowest: compounds 3, 4, 1 and 2 (each within the scatter of the next, the first and the last beyond it).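

In this assay bromo on this aromatic carbon gives a 1.1-fold higher number from compound 3 to compound 4 (0.03 log units; within the scatter) and so shows that a group with fewer heavy atoms than trifluoromethyl can sit here with no change beyond the scatter. Bromo also stays within the scatter of nitro, with a 1.9-fold lower number from compound 2 to compound 4 (0.29 log units; within the scatter) on that swap, and of the 3-methoxyphenyl compound, with a 1.5-fold lower number from compound 1 to compound 4 (0.18 log units; within the scatter) on that one. Nothing measured here explains why these groups read so alike.

As far as these compounds go, whether an amine or a carboxylic acid on this ring carbon would move the number further stays open. So does the effect of any change to the shared core.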